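The compounds below may be only part of what the source reports. "The series", "measured", "known", "first", "only" and "open" are said of these compounds alone.

Working notes on the series. Of the compounds shown here, two have been measured in an assay on isolated protein (Cavia porcellus) with cysteinyl leukotriene receptor (Homo sapiens) as the target; on this read-out lower numbers stand for lower potency and higher numbers for higher potency (the scale is a negative logarithm). Compound 1 `COc1cc(C(=O)NS(=O)(=O)c2ccccc2)ccc1Cc1cn(C)c2ccc(NC(=O)OC3CCCC3)cc12` gives 9.69 in this assay. Compound 2 `COc1cc(C(=O)NS(=O)(=O)c2ccccc2)ccc1Cc1c[nH]c2ccc(NC(=O)OC3CCCC3)cc12`, which carries hydrogen in place of methyl on the aromatic nitrogen, gives 9.8 in this assay. The step of a number 0.11 log units higher from compound 1 to compound 2 (within the scatter) shows that the exchange of methyl for hydrogen at this position leaves the number essentially unchanged. Compound 2 shows the higher of the two numbers, but the gap to compound 1 is within the scatter, so no order can be read from it.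

Compound 3 `CCCn1cc(Cc2ccc(C(=O)NS(=O)(=O)c3ccccc3)cc2OC)c2cc(NC(=O)OC3CCCC3)ccc21` is not yet measured. Its change from compound 2 is propyl in place of hydrogen on an aromatic nitrogen. Among the measured compounds shown here, the only measured step that bears on this position is a number 0.11 log units higher from compound 1 to compound 2 (within the scatter), a small alkyl group versus hydrogen on the same nitrogen, and it lay within the scatter. A longer chain at the same position is therefore expected to leave the number close to compound 2, and the expected step of a number 0.20 log units lower from compound 2 to compound 3 (within the scatter) is none beyond the scatter. Compound 3 is accordingly estimated at 9.6, with a range from 9.1 to 10.1.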

Compound 3, negative logarithm of the antagonist equilibrium constant: 8.44
The estimate for compound 3 lay 1.16 log units above the measured number; measured number below the stated range.
By their numbers in this assay, from the lowest: compound 3; then compounds 1 and 2 (each within the scatter of the next).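

In this assay, the aromatic nitrogen does not treat all alkyl groups alike: the methyl of compound 1 and the hydrogen of compound 2 stand within the scatter of each other, whereas propyl in place of hydrogen brings a large fall (a number 1.36 log units lower from compound 2 to compound 3 (beyond the scatter)). Read from the methyl compound, ethyl in place of hydrogen on the saturated chain carbon bound to the aromatic nitrogen gives a fall of similar kind (a number 1.25 log units lower from compound 1 to compound 3 (beyond the scatter)), so among these compounds the loss separates propyl from methyl and does not come with alkyl substitution on this nitrogen as such. Nothing at hand accounts for this fall.

From the compounds shown here alone, whether the number already falls with an ethyl group on this nitrogen, and whether it keeps falling or levels off with a butyl or longer chain, stays open. Also open, going by these compounds, is whether a branched isopropyl group, or a propyl chain ending in a hydroxyl group or a carboxylic acid, would sit near compound 2 or near compound 3 on this read-out.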